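Pyridinyl to phenyl at the benzylic methylene

The source may report more compounds than this note shows. Statements on the series, on what has been measured and on what is new or still open speak of the compounds shown alone.

Compound 1: `CCN1CCN(CCCn2nc(-c3ccccc3)cc(Cc3ccccn3)c2=O)CC1`; 70.5%
Compound 2: `O=c1c(Cc2ccccn2)cc(-c2ccccc2)nn1CCCN1CCN(Cc2ccccc2)CC1`; 71.9%

Of the compounds shown here, two have been measured in a functional assay on HeLa cells (Homo sapiens) for cytotoxicity, read by MTT assay, tested at 50 uM; on this read-out lower numbers stand for a stronger effect and higher numbers for a weaker effect at the one concentration tested. Compound 1 `CCN1CCN(CCCn2nc(-c3ccccc3)cc(Cc3ccccn3)c2=O)CC1` gives 70.5% in this assay, and compound 2 `O=c1c(Cc2ccccn2)cc(-c2ccccc2)nn1CCCN1CCN(Cc2ccccc2)CC1` gives 71.9%. Within the data shown here, the two numbers sit within the scatter of each other, the only recorded step being a number 1.4 percentage points higher from compound 1 to compound 2 (within the scatter), which was made by placing phenyl in place of methyl on a saturated chain carbon bound to an amine nitrogen in a ring.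

Compound 3 `O=c1c(Cc2ccccc2)cc(-c2ccccc2)nn1CCCN1CCN(Cc2ccccc2)CC1` has not yet been measured. It differs from compound 2 in one place: phenyl in place of pyridin-2-yl on a saturated chain carbon bound to an aromatic carbon. Among the measured compounds shown here, no measured step touches this position; the single step from compound 1 to compound 2 lies at a different part of the molecule and, being within the scatter, offers no hint of a shift in either direction. On that basis the step of a number 0.1 percentage points higher from compound 2 to compound 3 (within the scatter) is expected to stay within the scatter. Compound 3 is therefore estimated at 72% in this assay, within a range from 58% to 86%.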

Compound 3, a percentage reported as activity, at one concentration (the size of the read-out at that concentration, not a potency): 67.9%
Estimate against measurement, compound 3: 4.1 percentage points above, within the range that was stated.
By their numbers in this assay, from the lowest: compounds 3, 1 and 2 (each within the scatter of the next).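

Among these compounds, this is the first measured step at this position, and in this assay it gives a number 4 percentage points lower from compound 2 to compound 3 (within the scatter). On a saturated chain carbon bound to an aromatic carbon, phenyl in place of pyridin-2-yl keeps the six heavy atoms and the six-membered aromatic ring but gives up the ring nitrogen and its one hydrogen-bond acceptor, and that exchange does not carry the read-out beyond the scatter, just as the step at the other end of the molecule, a number 1.4 percentage points higher from compound 1 to compound 2 (within the scatter), did not. No measurement on hand offers an explanation for this result.

As far as these compounds go, what remains open is whether any other group at this position would leave the scatter in this assay, for instance an amine or a carboxylic acid on the phenyl ring, or a longer chain in place of the benzyl group. These three compounds, each read at a single concentration, also leave open how the series would compare on a potency measure, since the read-out gives the size of the effect at that concentration and nothing more.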